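This account rests on a few compounds, and the source may have more. Where it says the series, first, only, none or still open, it means among the compounds named here.

For the measured compounds named here, compound 2 `CC1CCN(C2CCN(S(=O)(=O)c3ccc(-c4ccccc4F)cc3)CC2)CC1` stands lowest of the two numbers measured so far in a functional assay on DLD-1 cells (Homo sapiens) for antiproliferative activity, read by CellTiter-Glo, with a stated time of 72 h (a higher number here means a weaker inhibitor, a lower number a stronger inhibitor), where compound 2 gives 5 nM. Going by the values given here, its nearest neighbour is compound 1 `COc1ccccc1-c1ccc(S(=O)(=O)N2CCC(N3CCC(C)CC3)CC2)cc1`, which in this assay gives 26 nM; the only measured step, a 5.2-fold lower number from compound 1 to compound 2 (0.72 log units; beyond the scatter), concerns fluoro in place of methoxy on an aromatic carbon. Compound 3 `CC1CCN(C2CCN(S(=O)(=O)c3ccc(-c4ccccc4)cc3)CC2)CC1` is still to be measured. It differs from compound 2 by hydrogen in place of fluoro on an aromatic carbon: fluoro leaves, hydrogen enters, on an aromatic carbon of a six-membered aromatic ring of carbon only, ortho to a large group, so that 2-fluorophenyl becomes phenyl. Among the compounds with values here, no measured step exchanges fluoro for hydrogen. Within the data shown here, the one step that exists, a 5.2-fold lower number from compound 1 to compound 2 (0.72 log units; beyond the scatter), bears on it only indirectly, showing that the group at this position can shift the number beyond the scatter. A small loss is expected on going to the unsubstituted ring, not a large one. Compound 3 is therefore estimated at 9 nM, with a range of 3 nM to 27 nM. This implies an expected 1.8-fold higher number from compound 2 to compound 3 (0.26 log units; within the scatter), which may still lie within the scatter.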

Compound 3, half-maximal inhibitory concentration: 258 nM
The estimate for compound 3 lay 29-fold (1.46 log units) below the measured number, and the stated range ends below it.
By their numbers in this assay, from the lowest: compound 2; then compound 1; then compound 3.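

Working from the unsubstituted ring as a reference, the place ortho to a large group is shown to matter far more than the earlier comparison of two substituents could reveal: in this assay there is a 52-fold higher number from compound 2 to compound 3 (1.71 log units; beyond the scatter), which makes 2-fluorophenyl to phenyl the largest change in the series so far. The methoxy compound also keeps an advantage over the unsubstituted ring, with a 9.9-fold higher number from compound 1 to compound 3 (1.00 log units; beyond the scatter), so among these three compounds the low numbers are not unique to fluoro, and both substituents outperform hydrogen here, with fluoro ahead of methoxy. No measurement at hand accounts for the size of the loss on removing fluoro.

On these data alone, it remains open whether a chloro, methyl or nitrile group in the same place would give a number like that of fluoro or methoxy, or whether a hydroxyl or an amine would fall closer to hydrogen. Also unresolved is whether fluoro on another carbon of this ring would recover any of the loss seen with compound 3.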